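A few compounds are considered here, and "the series" means these few. Any claim that something is new, unique, unknown or untested is made for them only; others in the source may bear on it.

Measured in a functional assay on HepG2 cells (Homo sapiens) for cytotoxicity, read by MTT assay; a higher number here means a weaker inhibitor, a lower number a stronger inhibitor:
- Compound 1 `COc1ccc(/C=C/C(=O)c2ccc(OC)c3c2OC(C)(C)C=C3)cc1OCCO`: > 10000 nM (a limit of the assay, not a number)
- Compound 2 `C=CC(=O)Oc1cc(/C=C/C(=O)c2ccc(OC)c3c2OC(C)(C)C=C3)ccc1OC`: 160 nM
- Compound 3 `COc1ccc(/C=C/C(=O)c2ccc(OC)c3c2OC(C)(C)C=C3)cc1CS(C)(=O)=O`: 9180 nM

Only two of these results are true numbers, and compound 3 holds the higher one, marking it as the weaker inhibitor of that pair. The gap is large: a 57-fold higher number from compound 2 to compound 3 (1.76 log units; beyond the scatter).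

Compound 4 `COc1ccc(/C=C/C(=O)c2ccc(OC)c3c2OC(C)(C)C=C3)cc1OS(=O)(=O)c1ccc(C)cc1` changes one group on the aromatic ring: ((4-methylphenyl)sulfonyl)oxy in place of (methylsulfonyl)methyl on an aromatic carbon. Among the compounds with values here, no measured compound carries the entering group, so the evidence is indirect. The step of an at least 1.0-fold lower number from compound 1 to compound 3 (0.03 log units; that floor lies within the scatter) shows that two different groups can both leave the result at the weak end. In contrast, an at least 62-fold lower number from compound 1 to compound 2 (1.79 log units; beyond the scatter) shows that a single group can shift it sharply, and compound 2 is the one exception to that weak end.

The weak end is the likelier home for the new group, so the expected step, a 1.5-fold lower number from compound 3 to compound 4 (0.18 log units; within the scatter), is not expected to go beyond the scatter. The chance of a compound 2-like drop still widens the range. Compound 4 is estimated at 6000 nM, with an expected range of 1000 nM to 20000 nM.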

Compound 4, half-maximal inhibitory concentration: 3600 nM
For compound 4 the middle estimate is 1.7-fold (0.22 log units) above the measured one; the measured number falls inside the stated range.
By their numbers in this assay, from the lowest: compound 2; then compound 4; then compound 3. At a limit, above all of these: compound 1.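

In this assay, ((4-methylphenyl)sulfonyl)oxy on this aromatic carbon, ortho to a methoxy group, moves the result clear of the scatter relative to (methylsulfonyl)methyl, with a 2.6-fold lower number from compound 3 to compound 4 (0.41 log units; beyond the scatter). There is also an at least 2.7-fold lower number from compound 1 to compound 4 (0.44 log units; beyond the scatter), a floor only, since that starting result is a limit and not a number: the limit of > 10000 nM in this assay, at which 1 of the 4 values shown sits. Vinylcarbonyl on the same oxygen remains far ahead, with a 23-fold higher number from compound 2 to compound 4 (1.35 log units; beyond the scatter), so not every group joined through that oxygen gives the low number.

The compounds shown leave open whether that low number needs the vinyl part of the group, which a propanoyl or acetyl group on the same oxygen would help to settle. They also do not tell how an amine or a carboxylic acid on this carbon would read.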